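A methylsulfanyl swap in a flat series

The source may hold more compounds than are shown below. What is called first, only, known or untested is meant among the compounds shown, and "the series" means these compounds.

Compound 1 `Clc1cc2ncn(C3CCCC3)c2cc1Cl` gives 42000 nM
Compound 2 `CCc1nc2cc(Cl)c(Cl)cc2n1C1CCCC1` gives 52000 nM
Compound 3 `CC(C)c1nc2cc(Cl)c(Cl)cc2n1C1CCCC1` gives 43000 nM

These numbers come from a functional assay on MCF7 cells (Homo sapiens) for cytotoxicity, read by MTT assay, with a stated time of 48 h (on this read-out higher numbers stand for weaker inhibition of growth and lower numbers for stronger inhibition of growth), and they lie close together. Compound 3 at 43000 nM cannot be told apart from the other two compounds. The steps read a 1.0-fold higher number from compound 1 to compound 3 (0.01 log units; within the scatter) and a 1.2-fold lower number from compound 2 to compound 3 (0.08 log units; within the scatter) and neither leaves the usual scatter. The step of a 1.2-fold higher number from compound 1 to compound 2 (0.09 log units; within the scatter) also stays inside it, so putting ethyl or isopropyl in place of hydrogen on this aromatic carbon has shifted nothing measurable so far.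

Compound 4 `CSc1nc2cc(Cl)c(Cl)cc2n1C1CCCC1` has not been measured yet. It carries methylsulfanyl in place of isopropyl on an aromatic carbon, the same carbon that varies in the three measured compounds. The counted change reads methylsulfanyl in place of isopropyl on an aromatic carbon and it lies between two ring nitrogen atoms. For the measured compounds named here, no measured compound carries methylsulfanyl, so the evidence is indirect and the uncertainty is wider than the scatter alone. With only these flat steps as a guide, no step beyond the scatter is expected in this assay in either direction. The estimated step is a 1.1-fold lower number from compound 3 to compound 4 (0.03 log units; within the scatter) and no larger shift is expected. Compound 4 is estimated at 40000 nM with an expected range from 17000 nM to 85000 nM for the coming measurement.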

Compound 4, concentration for 50% growth inhibition: 3900 nM
Estimate against measurement, compound 4: 10-fold (1.01 log units) above, and the stated range ends above it.
By their numbers in this assay, from the lowest: compound 4; then compounds 1, 3 and 2 (each within the scatter of the next).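

In this assay, the carbon between two ring nitrogen atoms proves far from indifferent. Hydrogen, ethyl and isopropyl there left the numbers within the scatter of one another, yet methylsulfanyl gives an 11-fold lower number from compound 3 to compound 4 (1.04 log units; beyond the scatter), as well as a 13-fold lower number from compound 2 to compound 4 (1.12 log units; beyond the scatter) and an 11-fold lower number from compound 1 to compound 4 (1.03 log units; beyond the scatter). All three steps lie beyond the scatter, so compound 4 is the most potent of the four at inhibiting growth, and the flat picture held only for hydrogen and the two alkyl groups. By the count of what changes, methylsulfanyl brings a sulfur atom and a hydrogen-bond acceptor, neither of which isopropyl has, but these counts alone do not show which feature, if either, matters.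

Nothing available here explains why this one group stands apart from the others. The compounds shown leave open whether the sulfur atom itself is needed, and methoxy, ethylsulfanyl or an amine on this same carbon would be the kind of comparison that could begin to separate these possibilities.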